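The source may hold more compounds than are shown below. What is called first, only, known or untested is meant among the compounds shown, and "the series" means these compounds.

Working notes on the series. Compound 1 `Cc1cc(OC(=O)c2ccc(CC(CO[N+](=O)[O-])O[N+](=O)[O-])cc2)n(-c2ccccc2)n1` gives 8 h in a physicochemical assay for metabolic stability, read by HPLC; on this read-out higher numbers stand for a longer-lived compound and lower numbers for a shorter-lived compound; compound 2 `Cc1cc(OC(=O)c2ccc(CCCO[N+](=O)[O-])cc2)n(-c2ccccc2)n1` gives 13 h; compound 3 `Cc1cc(OC(=O)c2ccc(OCC(CO[N+](=O)[O-])O[N+](=O)[O-])cc2)n(-c2ccccc2)n1` gives 25 h. The change hydrogen in place of nitrooxy on a saturated chain carbon bound to two saturated chain carbons gave a 1.6-fold higher number from compound 1 to compound 2 (0.21 log units; within the scatter). The same change, (hydrogen in place of nitrooxy on a saturated chain carbon bound to two saturated chain carbons), leads from compound 3 to the unmeasured compound 4 `Cc1cc(OC(=O)c2ccc(OCCCO[N+](=O)[O-])cc2)n(-c2ccccc2)n1`. How the core of compound 1 and the core of compound 3 differ is not broken down here. The two place lines read the same word for word, so the change is the same kind at the same kind of position. For compound 4 a step like the earlier one is expected, a 1.5-fold higher number from compound 3 to compound 4 (0.18 log units; within the scatter), resting on compound 1 to compound 2 having given a 1.6-fold higher number from compound 1 to compound 2 (0.21 log units; within the scatter). Compound 4 is therefore expected to show about 38 h, between 20 h and 70 h.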

Compound 4, half-life: 35 h
Estimate against measurement, compound 4: 1.1-fold (0.04 log units) above; the measured number falls inside the stated range.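

In this assay hydrogen in place of nitrooxy gives a 1.4-fold higher number from compound 3 to compound 4 (0.15 log units; within the scatter) on one core and a 1.6-fold higher number from compound 1 to compound 2 (0.21 log units; within the scatter) on the other, so the two cores agree only in that neither step stands clear of the scatter, and no real effect of the change is shown on either. Going by these compounds alone, the only step beyond the scatter belongs to a different change, 3-(nitrooxy)propoxy in place of 3-(nitrooxy)propyl on an aromatic carbon, which gives a 2.7-fold higher number from compound 2 to compound 4 (0.43 log units; beyond the scatter) and rests on this single pair. No measured evidence accounts for these results. The compounds shown leave open whether the step would read the same on any further core. Also open, from the compounds shown here alone, is how a carboxylic acid or a longer chain would read in place of nitrooxy.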